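The compounds below may be only part of what the source reports. "The series", "measured", "known", "first", "only" and "open" are said of these compounds alone.

In an ADME assay on L02 cells (Homo sapiens) for cytotoxicity, read by MTT assay, with a stated time of 24 h (on this read-out higher numbers stand for weaker inhibition and lower numbers for stronger inhibition), compound 1 (`N#Cc1ccc(/C=C2\CN(S(=O)(=O)c3ccc(F)cc3)C/C(=C\c3ccccc3F)C2=O)cc1`) gives 21900 nM and compound 2 (`COc1cc(/C=C2\CN(S(=O)(=O)c3ccc(F)cc3)C/C(=C\c3ccccc3F)C2=O)cc(OC)c1OC`) gives 17600 nM with no order between them. Among the compounds with values here, the one measured step (a 1.2-fold lower number from compound 1 to compound 2 (0.09 log units; within the scatter)) leaves compound 2 level with compound 1 on the numbers so far, and no other value exists to place it against.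

Compound 3 (`COc1cc(/C=C2\CN(S(=O)(=O)c3ccc(F)cc3)C/C(=C\c3ccccc3F)C2=O)cc(OC)c1`) keeps the shared core of compound 2 and differs in one place (hydrogen in place of methoxy on an aromatic carbon). This is hydrogen in place of methoxy on an aromatic carbon, so 3,4,5-trimethoxyphenyl becomes 3,5-dimethoxyphenyl.

Within the data shown here, no measured step removes a single methoxy. Among the measured compounds shown here, the only guide is the step that put 3,4,5-trimethoxyphenyl in place of 4-cyanophenyl (a 1.2-fold lower number from compound 1 to compound 2 (0.09 log units; within the scatter)). That whole-group exchange stayed within the scatter, which suggests a smaller edit on the same group may also do so, though two compounds are thin evidence. No step beyond the scatter is expected in this assay for this change. The estimated step (a 1.1-fold higher number from compound 2 to compound 3 (0.03 log units; within the scatter)) carries no firm direction. For compound 3 the expected value is 19000 nM (estimated range 9500 nM to 38000 nM).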

Compound 3, half-maximal inhibitory concentration: 18500 nM
The estimate for compound 3 lay 1.0-fold (0.01 log units) above the measured number; measured number inside the range.
By their numbers in this assay, from the lowest: compounds 2, 3 and 1 (each within the scatter of the next).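

Taking away the single methoxy, at the position ortho to two methoxy groups and para to a large group on the 3,4,5-trimethoxyphenyl ring, gives the first reading of that one position in this assay: a 1.1-fold higher number from compound 2 to compound 3 (0.02 log units; within the scatter), so hydrogen and methoxy there are not told apart by this read-out. The 3,5-dimethoxyphenyl group in place of 4-cyanophenyl also gives a 1.2-fold lower number from compound 1 to compound 3 (0.07 log units; within the scatter), and the three compounds now stand level, with none going against this: across these aryl groups, the number does not separate them. Nothing available bears on why the numbers stay level.

Going by these compounds, it remains open whether a hydroxyl group or an amine at this position, or a longer chain such as ethoxy or propoxy in place of the methoxy, would give a step beyond the scatter. All three compounds keep the rest of the shared core unchanged, so these notes say nothing about how the number responds to a change elsewhere on the molecule.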